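Nitro in Place of Trifluoromethyl: Compound 3 to Compound 4

The source may report more compounds than this note shows. Statements on the series, on what has been measured and on what is new or still open speak of the compounds shown alone.

The series shares one core, seen in compound 1 `Nc1ccccc1NC(=O)c1ccc(CNCc2nc(-c3ccc(C(F)(F)F)cc3)no2)cc1`, compound 2 `Nc1ccccc1NC(=O)c1ccc(CNCc2nc(-c3ccc(F)cc3)no2)cc1` and compound 3 `O=C(NO)c1ccc(CNCc2nc(-c3ccc(C(F)(F)F)cc3)no2)cc1`. Among the measured compounds shown here, in a functional assay on A549 cells (Homo sapiens) for inhibition, read by MTT assay, with a stated time of 72 h (a higher number here means a weaker inhibitor, a lower number a stronger inhibitor), compound 1 gives 100000 nM and compound 2 gives 10700 nM; the step of a 9.3-fold lower number from compound 1 to compound 2 (0.97 log units; beyond the scatter) is the only measured step with a readable size. In this assay compound 3 gives only a limit, > 100000 nM. The step of a number no lower from compound 1 to compound 3 (the limit leaves the size open) therefore has no readable size, and compound 3 sits at the limit of > 100000 nM in this assay, at which 1 of the 3 values shown sits.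

Compound 4 `O=C(NO)c1ccc(CNCc2nc(-c3ccc([N+](=O)[O-])cc3)no2)cc1` follows from compound 3 by one change: nitro in place of trifluoromethyl on an aromatic carbon. For the measured compounds named here, no measured step exchanges trifluoromethyl for nitro. Going by the values given here, the one measured step at this place, a 9.3-fold lower number from compound 1 to compound 2 (0.97 log units; beyond the scatter), concerns fluoro and belongs to partners whose amide carries 2-aminophenyl rather than hydroxy, so it guides only loosely. Since compound 3 gives no number, the step from it can only be read against the limit; it is expected to be a number no higher from compound 3 to compound 4 (the limit leaves the size open). For compound 4 the estimate in this assay is 100000 nM, with a range from 30000 nM to 300000 nM, and a real chance that again only a limit is reported.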

Compound 4, half-maximal inhibitory concentration: > 100000 nM
Compound 4: only a limit was reported (the forecaster's own chance of this, stated with the estimate: 60%); the middle value sits exactly at the limit.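

Compound 3 and compound 4 each give only a limit in this assay, so the change from trifluoromethyl to nitro yields no readable step: the limit of > 100000 nM in this assay, at which 2 of the 4 values shown sit.

The compounds shown leave open whether nitro or trifluoromethyl gives the lower number when hydroxy sits on the amide-type nitrogen.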